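Furan in Place of Phenyl on a Lipid Phosphate Nucleoside

The source may report more compounds than this note shows. Statements on the series, on what has been measured and on what is new or still open speak of the compounds shown alone.

The measured compounds and their values:
compound 1, `OC[C@H]1O[C@@H](n2cc(F)c3c(-c4ccccc4)ncnc32)[C@H](O)[C@@H]1O`: > 50000 nM
compound 2, `OC[C@H]1O[C@@H](n2cc(F)c3c(-c4ccco4)ncnc32)[C@H](O)[C@@H]1O`: 310 nM
compound 3, `CCCCCCCCCCCCCCCCCCOP(=O)(O)OC[C@H]1O[C@@H](n2ccc3c(-c4ccccc4)ncnc32)[C@H](O)[C@@H]1O`: > 50000 nM

In an ADME assay on BJ cells (Homo sapiens) for cytotoxicity, read by MTT assay, with a stated time of 72 h (a higher number here means that more compound is tolerated, a lower number that less compound is tolerated), compound 1 gives > 50000 nM, which is a limit of the assay and not a number. Compound 2 gives 310 nM. The change between them is furan-2-yl in place of phenyl on an aromatic carbon, and it made a step of an at least 160-fold lower number from compound 1 to compound 2 (2.20 log units; beyond the scatter).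

Compound 3 gives > 50000 nM in this assay, again a limit rather than a number. Compound 3 differs from compound 1 in more than one place; the difference between the two cores is not broken down here.

Compound 4, `CCCCCCCCCCCCCCCCCCOP(=O)(O)OC[C@H]1O[C@@H](n2ccc3c(-c4ccco4)ncnc32)[C@H](O)[C@@H]1O`, has not been measured. It carries the same change as that from compound 1 to compound 2: furan-2-yl in place of phenyl on an aromatic carbon. The direction of the step from compound 3 to compound 4 is expected to follow the earlier one, but its size is uncertain, since compound 3 sits at the limit of > 50000 nM in this assay, at which 2 of the 3 values shown sit. The estimated step is an at least 16-fold lower number from compound 3 to compound 4 (1.22 log units; beyond the scatter). For compound 4 the expected value is 3000 nM, with a likely range from 300 nM to 30000 nM.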

Compound 4, half-maximal cytotoxic concentration: > 50000 nM
Compound 4: only a limit was reported; the forecaster's own chance of this, stated with the estimate: 30%; at least 16-fold (1.22 log units) between middle value and limit.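

In this assay, compound 3 and compound 4 both stand at a limit of the assay and not at a number, so no step can be read between them: the limit of > 50000 nM in this assay, at which 3 of the 4 values shown sit. The compounds shown leave open whether furan-2-yl in place of phenyl on the core of compound 3 changes the tolerated concentration at all, and by how much.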